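This account rests on a few compounds, and the source may have more. Where it says the series, first, only, none or still open, it means among the compounds named here.

Measured so far (in a functional assay on COLO 205 cells (Homo sapiens) for cytotoxicity, read by MTT assay, with a stated time of 48 h; a higher number here means a weaker inhibitor, a lower number a stronger inhibitor):
- compound 1 (`O=c1ccc2cc(OCc3cc(-c4ccccc4)no3)ccc2o1`), result ("not determined" (no result reported))
- compound 2 (`O=c1ccc2cc(OCc3cc(-c4cccc5ccccc45)no3)ccc2o1`), result (47200 nM)

Compound 1 offers no number to start from, since its entry in this assay reads ("not determined" (no result reported)). The next compound, compound 3 (`O=c1ccc2cc(OCc3cc(-c4ccc(Cl)cc4)no3)ccc2o1`), still awaits testing. It differs from compound 1 in one place (chloro in place of hydrogen on an aromatic carbon): chloro in place of hydrogen on an aromatic carbon, which turns phenyl to 4-chlorophenyl. Going by the values given here, no measured pair shows what this kind of change does, so no direction can be argued, and no step beyond the usual scatter is expected. Among the compounds with values here, the best available anchor is compound 2 (47200 nM), the one number in this small set. For compound 3 the expected value is (40000 nM), with an estimated range from (12000 nM) to (100000 nM).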

Compound 3, half-maximal inhibitory concentration: 44500 nM
Beside the measured number, compound 3's estimate is 1.1-fold (0.05 log units) below it; low and high end bracket the measured number.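

In this assay no step can be read from compound 1 to compound 3, as compound 1 has no number to compare. On these data alone, what chloro in place of hydrogen does to the value therefore stays open. No supporting evidence bears on the result of compound 3.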